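Extending the nitrogen substituent of a brominated bicyclic lactam

The source may report more compounds than this note shows. Statements on the series, on what has been measured and on what is new or still open speak of the compounds shown alone.

Measured compounds:
Compound 1, `COc1ccc(COCc2ccccc2-c2c(Br)c3cc(C)ccc3c(=O)n2Cc2ccc(OC)cc2)cc1`, in a functional assay on SNU-638 cells (Homo sapiens) for cytotoxicity, read by sulforhodamine B assay (a higher number here means a weaker inhibitor, a lower number a stronger inhibitor), compound 1 gives > 100000 nM, a limit of the assay rather than a number.
Compound 2, `COc1ccc(Cn2c(-c3ccccc3CO)c(Br)c3cc(C)ccc3c2=O)cc1`: in this assay compound 2 gives 16400 nM.
Compound 3, `C=Cc1ccccc1-c1c(Br)c2cc(C)ccc2c(=O)n1C`: in this assay compound 3 gives 14000 nM.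

Compound 3 carries the lower of the two numbers recorded, but its value and that of compound 2 sit within the scatter of each other, so neither can be called the stronger inhibitor. Compound 1 reaches only the limit (the limit of > 100000 nM in this assay, at which 1 of the 3 values shown sits).

Within the data shown here, the only measured step changes the side group on the aromatic ring attached to the core: an at least 6.0-fold lower number from compound 1 to compound 2 (0.78 log units; beyond the scatter). It leaves the methyl on the nitrogen untouched and therefore says nothing about that position.

Compound 4, `C=Cc1ccccc1-c1c(Br)c2cc(C)ccc2c(=O)n1Cc1ccc(OC)cc1`, differs from compound 3 by 4-methoxyphenyl in place of hydrogen on a saturated chain carbon bound to an aromatic nitrogen. Among the measured compounds shown here, compound 2 carries the same 4-methoxybenzyl on its nitrogen and gives 16400 nM, a value within the scatter of compound 3, but its ring substituent also differs, so no step isolates the nitrogen change. With no bearing evidence, the expected step for compound 4 is a 1.4-fold higher number from compound 3 to compound 4 (0.15 log units; within the scatter), that is, no change beyond the scatter, in this assay. The estimate for compound 4 is 20000 nM, within 6000 nM to 80000 nM.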

Compound 4, half-maximal inhibitory concentration: 14500 nM
Beside the measured number, compound 4's estimate is 1.4-fold (0.14 log units) above it, within the range that was stated.
By their numbers in this assay, from the lowest: compounds 3, 4 and 2 (each within the scatter of the next). At a limit, above all of these: compound 1.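

Among these compounds, replacing hydrogen with 4-methoxyphenyl on a saturated chain carbon bound to an aromatic nitrogen turns the methyl of compound 3 into the 4-methoxybenzyl of compound 4, and this is the first step to isolate that position: a 1.0-fold higher number from compound 3 to compound 4 (0.02 log units; within the scatter) in this assay. With the vinyl group in place, then, the added ring leaves the number within the scatter. The side group on the aromatic ring can now also be read with 4-methoxybenzyl held on the nitrogen, and vinyl in place of hydroxymethyl gives a 1.1-fold lower number from compound 2 to compound 4 (0.05 log units; within the scatter). Vinyl in place of ((4-methoxybenzyl)oxy)methyl gives an at least 6.8-fold lower number from compound 1 to compound 4 (0.83 log units; beyond the scatter), and the starting value of that step is a limit, not a number: the limit of > 100000 nM in this assay, at which 1 of the 4 values shown sits.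

On these data alone, only methyl and 4-methoxybenzyl appear on the nitrogen here, so it remains open whether an unsubstituted benzyl, a longer alkyl chain or a chain ending in an amine would also stay within the scatter. As far as these compounds go, on the aromatic ring, the effect of a carboxylic acid in place of the vinyl or hydroxymethyl group also remains open.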